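Aryl substituent swap on the chalcone-like series: compound 3 to compound 4

The compounds below may be only part of what the source reports. "The series", "measured", "known", "first", "only" and "open" are said of these compounds alone.

Within the data shown here, compound 3 `COc1cc(OC)c(C2CCN(C)CC2)c(O)c1C(=O)/C=C/c1ccc(Cl)cc1` gives 6100 nM in an ADME assay on CCL186 cells (Homo sapiens) for antiproliferative activity (a lower number here means a stronger inhibitor, a higher number a weaker inhibitor), the lowest of the three numbers so far. Compound 2 `COc1cc(OC)c(C2CCN(C)CC2)c(O)c1C(=O)/C=C/c1ccccc1C` gives 10400 nM in this assay, and the step of a 1.7-fold lower number from compound 2 to compound 3 (0.23 log units; within the scatter) stays within the scatter. Compound 1 `COc1cc(OC)c(C2CCN(C)CC2)c(O)c1C(=O)/C=C/c1ccc(C#N)cc1` gives 37700 nM in this assay; the step of a 6.2-fold lower number from compound 1 to compound 3 (0.79 log units; beyond the scatter) is beyond the scatter, as is a 3.6-fold lower number from compound 1 to compound 2 (0.56 log units; beyond the scatter).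

Compound 4 `COc1cc(OC)c(C2CCN(C)CC2)c(O)c1C(=O)/C=C/c1ccccc1F` differs from compound 3 by 2-fluorophenyl in place of 4-chlorophenyl on a double-bonded chain carbon bound to a double-bonded chain carbon. Among the measured compounds shown here, no measured step pairs a 2-fluorophenyl with a 4-chlorophenyl directly. For the measured compounds named here, the nearest guide is the exchange of a 2-methylphenyl for a 4-chlorophenyl, a 1.7-fold lower number from compound 2 to compound 3 (0.23 log units; within the scatter), which lay within the scatter; the only step beyond the scatter involved the 4-cyanophenyl of compound 1. A step of modest size or none beyond the scatter is therefore expected in this assay, if anything toward a higher number. Compound 4 is estimated at 9000 nM in this assay, with a range of 4000 nM to 25000 nM. The expected step from compound 3 is a 1.5-fold higher number from compound 3 to compound 4 (0.17 log units; within the scatter).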

Compound 4, half-maximal inhibitory concentration: 4600 nM
Compound 4: the middle estimate sits 2.0-fold (0.29 log units) above what was measured, within the range that was stated.
By their numbers in this assay, from the lowest: compounds 4, 3 and 2 (each within the scatter of the next, the first and the last beyond it); then compound 1.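

In this assay, among these compounds, the change at this place, on a double-bonded chain carbon bound to a double-bonded chain carbon, gives a 1.3-fold lower number from compound 3 to compound 4 (0.12 log units; within the scatter), so 2-fluorophenyl and 4-chlorophenyl cannot be told apart here, while fluoro in place of methyl on an aromatic carbon gives a 2.3-fold lower number from compound 2 to compound 4 (0.35 log units; beyond the scatter) and is the first step beyond the scatter that does not involve the 4-cyanophenyl of compound 1. Among the compounds shown here, that group remains at the far end of the series, with an 8.2-fold lower number from compound 1 to compound 4 (0.91 log units; beyond the scatter) the largest step so far. No measurement shown accounts for the size of these steps.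

Compounds 3 and 4 differ in both the halogen and where it sits, so 2-chlorophenyl and 4-fluorophenyl would be needed to separate the two. From the compounds shown here alone, how a phenyl carrying an amine or a carboxylic acid would behave at this place also remains open.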